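A few compounds are considered here, and "the series" means these few. Any claim that something is new, unique, unknown or untested is made for them only; others in the source may bear on it.

Within the data shown here, in a functional assay on A549 cells (Homo sapiens) for cytotoxicity, read by MTT assay, with a stated time of 48 h (on this read-out lower numbers stand for stronger inhibition and higher numbers for weaker inhibition), compound 2 `CCOC(=O)[C@]1(C(=O)Nc2ccccc2)C[C@@H]1c1cc(OC)c(OC)c(OC)c1` gives 21300 nM, the only actual number among the three compounds tested. Compound 1 `CCOC(=O)[C@@]1(C(=O)Nc2ccccc2)C[C@@H]1c1cc(OC)c(OC)c(OC)c1` reads > 100000 nM, which is a limit of the assay and not a number. Compound 3 `COc1cc([C@H]2C[C@]2(CO)C(=O)Nc2ccccc2)cc(OC)c1OC` reads > 100000 nM, which is also a limit.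

Compound 4 `CCOC(=O)[C@]1(C(=O)NCc2ccc(C)cc2)C[C@@H]1c1cc(OC)c(OC)c(OC)c1` differs from compound 2 at one place: 4-methylbenzyl in place of phenyl on an amide-type nitrogen. Neither measured step changes this group. The step of an at least 4.6-fold lower number from compound 1 to compound 2 (0.67 log units; beyond the scatter) reflects (the fact that compounds 1 and 2 differ only in the configuration as drawn), and the step of an at least 4.6-fold higher number from compound 2 to compound 3 (0.67 log units; beyond the scatter) replaces ethoxycarbonyl with hydroxymethyl on a saturated ring carbon. Among the measured compounds shown here, both lie beyond the scatter, but they show only that compound 2 can lose its measurable activity, and they give no direct size for the new change.

The expected change is small and within the scatter, leaning towards a higher number, and is written as a 1.4-fold higher number from compound 2 to compound 4 (0.15 log units; within the scatter). For compound 4, the estimated value is 30000 nM, with an expected range from 8000 nM to 100000 nM.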

Compound 4, half-maximal inhibitory concentration: 34900 nM
Beside the measured number, compound 4's estimate is 1.2-fold (0.07 log units) below it, and the stated range covers the measured number.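

On the amide-type nitrogen, putting 4-methylbenzyl in place of phenyl gives a 1.6-fold higher number from compound 2 to compound 4 (0.21 log units; within the scatter) in this assay, so the two groups cannot be told apart in this assay. Among these compounds, the earlier steps changed only the configuration at a saturated ring carbon and the ethoxycarbonyl group, so this is the first reading of a change at this nitrogen, and here a group of 8 heavy atoms reads like one of 6. Nothing shown explains why the two groups read alike.

Going by these compounds, it remains open how the methyl group and the extra carbon of the benzyl link each count, which plain benzyl could help to separate. On these data alone, it is also open whether this nitrogen would respond differently to a longer chain such as 3-phenylpropyl, or to a group carrying an amine, such as 2-aminoethyl.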